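Acetyl in place of tert-butoxycarbonyl on the pyrrolidine

This account rests on a few compounds, and the source may have more. Where it says the series, first, only, none or still open, it means among the compounds named here.

In an assay on isolated protein for binding affinity to secreted frizzled-related protein 1 (Homo sapiens), read by fluorescence (a lower number here means a stronger inhibitor, a higher number a weaker inhibitor), compound 3 `CC(C)(C)OC(=O)N1CCC[C@@H]1C(=O)N1CCC(NS(=O)(=O)c2cc(S(=O)(=O)c3ccccc3)ccc2C(F)(F)F)CC1` gives 120 nM, the second highest of three numbers. Compound 1 `O=C(CN1CCNCC1)N1CCC(NS(=O)(=O)c2cc(S(=O)(=O)c3ccccc3)ccc2C(F)(F)F)CC1` gives 140 nM, and the step of a 1.2-fold lower number from compound 1 to compound 3 (0.07 log units; within the scatter). Compound 2 `CC(C)(C)OC(=O)N1CCC[C@H]1C(=O)N1CCC(NS(=O)(=O)c2cc(S(=O)(=O)c3ccccc3)ccc2C(F)(F)F)CC1` gives 60 nM; the step of a 2.0-fold higher number from compound 2 to compound 3 (0.30 log units; within the scatter), noting (the fact that compounds 2 and 3 differ only in the configuration as drawn). The step of a 2.3-fold lower number from compound 1 to compound 2 (0.37 log units; beyond the scatter) was the only one beyond the scatter.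

Compound 4 `CC(=O)N1CCC[C@H]1C(=O)N1CCC(NS(=O)(=O)c2cc(S(=O)(=O)c3ccccc3)ccc2C(F)(F)F)CC1` carries 1-acetylpyrrolidin-2-yl in place of 1-(tert-butoxycarbonyl)pyrrolidin-2-yl on a carbonyl carbon. Among the measured compounds shown here, no measured step alters this part of the molecule, and the steps that touched the carbonyl substituent, a 2.3-fold lower number from compound 1 to compound 2 (0.37 log units; beyond the scatter) and a 1.2-fold lower number from compound 1 to compound 3 (0.07 log units; within the scatter), were modest or within the scatter. Compound 4 is therefore expected to show no step beyond the scatter, no change at the digits printed from compound 3 to compound 4 (within the scatter). Compound 4 is estimated at 120 nM, with a range from 50 nM to 300 nM.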

Compound 4, half-maximal inhibitory concentration: 160 nM
Compound 4: the middle estimate sits 1.3-fold (0.12 log units) below what was measured; the range from low to high includes it.
By their numbers in this assay, from the lowest: compounds 2, 3, 1 and 4 (each within the scatter of the next, the first and the last beyond it).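

With the drawn configuration held, methyl in place of tert-butoxy on the carbonyl carbon gives a 2.7-fold higher number from compound 2 to compound 4 (0.43 log units; beyond the scatter), so the tert-butoxy end of this substituent makes a modest difference in this assay. The step of a 1.3-fold higher number from compound 3 to compound 4 (0.12 log units; within the scatter) changes the drawn configuration as well as the cap, the stereocentre of the acetyl compound being drawn as in compound 2: the fact that compounds 2 and 3 differ only in the configuration as drawn. The step of a 1.1-fold higher number from compound 1 to compound 4 (0.06 log units; within the scatter) does not separate 1-acetylpyrrolidin-2-yl from (piperazin-1-yl)methyl. Still open, as far as these compounds go, is how the acetyl cap behaves with the opposite configuration, and whether a free pyrrolidine amine or a longer acyl chain such as propanoyl would track the tert-butoxycarbonyl or the acetyl compounds.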